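Replacing the aryl ether end of compound 1 with a naphthalene

The compounds below may be only part of what the source reports. "The series", "measured", "known", "first", "only" and "open" are said of these compounds alone.

Compound 1 `Cc1cc(Oc2ccc(/C=N/NC(=S)Nc3ccc(F)cc3)cc2)ccc1Cl` was examined in a physicochemical assay for lipophilicity, in phosphate buffer, measured as octanol-water partition, with a stated time of 24 h (a lower number here means a more polar compound, a higher number a more lipophilic compound), where compound 1 gives 6.07. Among the measured compounds shown here, only one other compound shares this measurement: compound 2 `S=C(N/N=C/c1ccc(Oc2ccccc2)cc1)Nc1ccc(Br)cc1`, for which compound 2 gives 6.38. On these two numbers compound 1 stands lowest, and the value of compound 2 lies higher by an amount beyond the usual scatter. For the measured compounds named here, no pair differing in one place has been measured, so no single-change step is known from this series.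

Compound 3 `Fc1ccc(NC(=S)N/N=C/c2ccc(Oc3ccc4ccccc4c3)cc2)cc1` has not yet been measured. It differs from compound 1 in one place: naphthalen-2-yl in place of 4-chloro-3-methylphenyl on an oxygen on an aromatic ring. Going by the values given here, with no directly comparable step available, the expectation rests only on the values of compound 1 and compound 2, and the step from compound 1 to compound 3 is expected to be small, a number 0.13 log units higher from compound 1 to compound 3 (within the scatter), in either direction or within the scatter. In this assay compound 3 is therefore estimated at 6.2, between 5.7 and 6.7.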

Compound 3, partition coefficient: 6.2
Compound 3: middle estimate and measured number agree at the digits printed; low and high end bracket the measured number.
By their numbers in this assay, from the lowest: compounds 1, 3 and 2 (each within the scatter of the next, the first and the last beyond it).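

In this assay, among the compounds shown here, the first single-change step, naphthalen-2-yl in place of 4-chloro-3-methylphenyl on an oxygen on an aromatic ring, gives a number 0.13 log units higher from compound 1 to compound 3 (within the scatter). At this position, therefore, one six-membered aromatic ring of carbon only, carrying the chlorine and the methyl, can give way to 2 such rings with no difference beyond the scatter, so the two compounds cannot be told apart here. No measurement at hand bears on why this exchange leaves the two numbers so close.

From the compounds shown here alone, it remains open how this assay would read with an amine, a carboxylic acid or a longer alkyl chain on the same oxygen. Also open, going by these compounds, is whether naphthalen-2-yl would read the same way with the rest of the core of compound 3 altered.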